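The compounds below may be only part of what the source reports. "The series", "measured", "known", "first", "only" and "open" are said of these compounds alone.

In a functional assay on HL-60 cells (Homo sapiens) for antiproliferative activity, read by MTT assay, with a stated time of 6 days (a higher number here means a weaker inhibitor, a lower number a stronger inhibitor), compound 1 `CC(=O)O[C@@H]1C=CC(=O)O[C@@H]1[C@@H](COC(=O)c1ccc([N+](=O)[O-])cc1)OC(C)=O` gives 1110 nM and compound 2 `O=C1C=C[C@@H](OCc2ccccc2)[C@@H]([C@@H](COC(=O)/C=C/c2ccccc2)OCc2ccccc2)O1` gives 610 nM. These two numbers lie within the usual scatter of repeated measurements, so the data cannot rank one of these compounds over the other. Compound 3 `O=C1C=C[C@@H](OCc2ccccc2)[C@@H]([C@@H](COC(=O)/C=C/c2ccc(F)cc2)OCc2ccccc2)O1` is compound 2 with a single small edit: fluoro in place of hydrogen on an aromatic carbon, para to a large group. The measured compounds offer no direct guide to this swap, since they do not form a pair that differs in one place only. With so little to go on, no step beyond the scatter is expected in this assay, and neither direction is favoured. The expected step is a 1.1-fold lower number from compound 2 to compound 3 (0.04 log units; within the scatter). For compound 3 the estimated value is 550 nM, with an expected range from 230 nM to 1300 nM.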

Compound 3, half-maximal inhibitory concentration: 5400 nM
Estimate against measurement, compound 3: 9.8-fold (0.99 log units) below; the measured number lies above the stated range.
By their numbers in this assay, from the lowest: compounds 2 and 1 (each within the scatter of the next); then compound 3.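

In this assay, the swap of phenyl to 4-fluorophenyl gives an 8.9-fold higher number from compound 2 to compound 3 (0.95 log units; beyond the scatter) and so shows that this spot on the aromatic ring, para to a large group, is sensitive to what it carries. Compound 1 and compound 2 differ in more than one place, so they could not reveal this; here a single added fluorine atom is enough to make the compound a clearly weaker inhibitor. No supporting measurement is available to explain this step.

Going by these compounds, whether this sensitivity is specific to fluoro or extends to other groups remains open, and a chloro, methoxy or amino group in the same place would help to separate those possibilities. On these data alone, the effect of fluoro elsewhere on this ring also remains unknown.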